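The source may hold more compounds than are shown below. What is called first, only, known or untested is meant among the compounds shown, and "the series" means these compounds.

Three compounds share one core and differ only in the group carried on an aromatic carbon of the fused ring at the chain's end. Compound 1 `O=c1cc(-c2ccccc2)oc2cc(OCCCCNc3nc4ccc([N+](=O)[O-])cc4s3)cc(O)c12` carries a nitro group there, and in a physicochemical assay, read by spectrophotometry, with a stated time of 10 min (a higher number here means a weaker inhibitor, a lower number a stronger inhibitor), compound 1 gives 8.14 ug/mL. Compound 2 `O=c1cc(-c2ccccc2)oc2cc(OCCCCNc3nc4ccc(Cl)cc4s3)cc(O)c12` carries chloro, and in this assay compound 2 gives 4.16 ug/mL. Compound 3 `O=c1cc(-c2ccccc2)oc2cc(OCCCCNc3nc4ccc(I)cc4s3)cc(O)c12` carries iodo, and in this assay compound 3 gives 9.84 ug/mL. Compound 3 thus sits at the top of the three numbers; compound 1 is its nearest neighbour, with a 1.2-fold higher number from compound 1 to compound 3 (0.08 log units; within the scatter), and compound 2 its furthest, with a 2.4-fold higher number from compound 2 to compound 3 (0.37 log units; beyond the scatter). The remaining comparison, a 2.0-fold lower number from compound 1 to compound 2 (0.29 log units; within the scatter), is likewise small.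

Compound 4 `O=c1cc(-c2ccccc2)oc2cc(OCCCCNc3nc4ccc(C(F)(F)F)cc4s3)cc(O)c12` continues the same series: trifluoromethyl in place of iodo on an aromatic carbon. All three measured steps bear on this change, since each exchanged the substituent at this very carbon, and none moved the number by more than a modest amount. The expectation for compound 4 in this assay is therefore a small step, not clearly beyond the scatter, with the direction uncertain. Compound 4 is estimated at 7 ug/mL, within a range of 3.5 ug/mL to 14 ug/mL. This estimate means a step of a 1.4-fold lower number from compound 3 to compound 4 (0.15 log units; within the scatter), which is expected to stay inside the spread already seen.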

Compound 4, half-maximal inhibitory concentration: 4.95 ug/mL
For compound 4 the middle estimate is 1.4-fold (0.15 log units) above the measured one; measured number inside the range.
By their numbers in this assay, from the lowest: compounds 2, 4, 1 and 3 (each within the scatter of the next, the first and the last beyond it).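

At this aromatic carbon, trifluoromethyl brings 4 heavy atoms where iodo brought 1, yet the change stays within the scatter, at a 2.0-fold lower number from compound 3 to compound 4 (0.30 log units; within the scatter); the same is true of a 1.2-fold higher number from compound 2 to compound 4 (0.08 log units; within the scatter) and of a 1.6-fold lower number from compound 1 to compound 4 (0.22 log units; within the scatter). The earlier compounds shown here held one step beyond the scatter, from chloro to iodo, and compound 4 now lies within the scatter of both of those compounds, so in this assay the four groups form one continuous run of numbers rather than two separate levels, with only its two ends, compound 2 and compound 3, printed as apart. Nothing available gives a reason for these numbers.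

The compounds shown leave open whether an amine, a carboxylic acid or a hydroxyl group on this same carbon would stay inside this narrow run, since only nitro, chloro, iodo and trifluoromethyl appear there. They also leave open whether a shorter or longer chain than the one shared by all four compounds, or trifluoromethyl on another carbon of that six-membered ring, would move the number further.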